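A few compounds are considered here, and "the series" means these few. Any claim that something is new, unique, unknown or untested is made for them only; others in the source may bear on it.

Compound 1 `C=CCOc1nc(N)nc2c1ncn2/C=C1/CC1(CO)CO` is the starting point of this comparison. In an ADME assay on BCBL1 cells (Homo sapiens) for cytotoxicity, with a stated time of 7 days (a higher number here means that more compound is tolerated, a lower number that less compound is tolerated), compound 1 gives > 20000 nM, which is a limit of the assay rather than a number. Two neighbours share the core of compound 1 and differ from it in one place. Compound 2 `CCCCCCCCOc1nc(N)nc2c1ncn2/C=C1/CC1(CO)CO` carries an octyloxy group, and in this assay compound 2 gives > 20000 nM, again a limit. Compound 3 `CN(C)c1nc(N)nc2c1ncn2/C=C1/CC1(CO)CO` carries a dimethylamino group, and in this assay compound 3 gives > 20000 nM, also a limit. Because all three values sit at the limit of > 20000 nM in this assay, at which 3 of the 3 values shown sit, none of the three steps can be read: a step that the two limits leave unreadable from compound 1 to compound 2, a step that the two limits leave unreadable from compound 1 to compound 3 and a step that the two limits leave unreadable from compound 2 to compound 3 are all left open by the limits.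

Compound 4 `CCCCCCSc1nc(N)nc2c1ncn2/C=C1/CC1(CO)CO` has not yet been measured. It differs from compound 1 in one place: hexylsulfanyl in place of allyloxy on an aromatic carbon. The measured steps that bear on this change are the two starting from compound 1, and each of them is unreadable. Three compounds resting at the same limit give no sign that the group on this aromatic carbon moves the read-out within the tested range. The step expected here is a number no higher from compound 1 to compound 4 (the limit leaves the size open), that is, none beyond the scatter. Compound 4 is therefore estimated at 20000 nM, within 8000 nM to 50000 nM, most likely reported again as a limit.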

Compound 4, half-maximal cytotoxic concentration: > 20000 nM
Compound 4 was reported as a limit; the forecaster's own chance of this, stated with the estimate: 85%; the middle value lies on the limit itself.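

In this assay compound 4 gives > 20000 nM, a limit of the assay. None of the steps joining compound 4 to compound 1, compound 2 and compound 3 can be read, because all four compounds rest at the same limit: the limit of > 20000 nM in this assay, at which 4 of the 4 values shown sit.

The compounds shown leave open whether the group on this aromatic carbon changes the half-maximal cytotoxic concentration at all.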